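Trading a Dipropylamino Group for an Azetidine Ring

The source may report more compounds than this note shows. Statements on the series, on what has been measured and on what is new or still open speak of the compounds shown alone.

Compound 1 `O=C1C(Nc2cccc(Cl)c2)=CC(=O)c2c1nc1n2[C@H]2OC[C@@H](O)[C@H]2OC1` gives 7970 nM in a functional assay on HeLa cells (Homo sapiens) for inhibition, read by sulforhodamine B assay; a higher number here means a weaker inhibitor, a lower number a stronger inhibitor.
Compound 2 `O=C1C(NCc2ccccc2)=CC(=O)c2c1nc1n2[C@H]2OC[C@@H](O)[C@H]2OC1` gives 11000 nM.
Compound 3 `CCCN(CCC)C1=CC(=O)c2c(nc3n2[C@H]2OC[C@@H](O)[C@H]2OC3)C1=O` reaches only the limit > 16000 nM, which is not a number.

Compound 3 thus stands at the edge of what the measurement reports, as the limit of > 16000 nM in this assay, at which 1 of the 3 values shown sits, shows. The steps into it were an at least 2.0-fold higher number from compound 1 to compound 3 (0.30 log units; that floor lies within the scatter) and an at least 1.4-fold higher number from compound 2 to compound 3 (0.16 log units; that floor lies within the scatter), and a 1.4-fold higher number from compound 1 to compound 2 (0.14 log units; within the scatter) was also small. The change now is azetidin-1-yl in place of dipropylamino on a double-bonded ring carbon. Going by the values given here, no measured step swaps one amine group for another on that carbon while keeping a ring-closed amine, so the expectation rests on compound 3 alone. Compound 4 `O=C1C(N2CCC2)=CC(=O)c2c1nc1n2[C@H]2OC[C@@H](O)[C@H]2OC1` is expected to stay near that limit, with a number no higher from compound 3 to compound 4 (the limit leaves the size open), and may again report only a limit. The estimate for compound 4 is 16000 nM, between 6000 nM and 40000 nM.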

Compound 4, half-maximal inhibitory concentration: > 16000 nM
Compound 4: only a limit was reported (the forecaster's own chance of this, stated with the estimate: 60%); the middle value lies on the limit itself.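

In this assay, compound 4 gives only a limit, as compound 3 does, so a small azetidin-1-yl ring on this double-bonded ring carbon gives the same kind of result as the open dipropylamino group, and the step between them cannot be read. The steps from the other two amines are an at least 1.4-fold higher number from compound 2 to compound 4 (0.16 log units; that floor lies within the scatter) and an at least 2.0-fold higher number from compound 1 to compound 4 (0.30 log units; that floor lies within the scatter), so neither establishes a real loss. The limit now recurs for two different amines: the limit of > 16000 nM in this assay, at which 2 of the 4 values shown sit.

As far as these compounds go, whether a morpholine ring or an unsubstituted amine on this carbon would give a readable number stays open.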